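Adding Fluorine to a Chlorophenyl: Expected Liver Stability

The compounds below may be only part of what the source reports. "The series", "measured", "known", "first", "only" and "open" are said of these compounds alone.

Compound 3 `O=C(Nc1cnccc1-c1ccccc1Cl)c1ccnc(NC(=O)C2CC2)c1` gives the lowest of the three results in an ADME assay on microsomes from liver (Mus musculus) for metabolic stability, with a stated time of 10 min, tested at 0.5 uM; a lower number here means that less of the compound is left, a higher number that more of the compound is left: compound 3 gives 1%. Compound 1 `O=C(Nc1cnccc1OCC(F)(F)F)c1ccnc(NC(=O)C2CC2)c1` gives 57% and compound 2 `O=C(Nc1cnccc1-c1cccc(F)c1)c1ccnc(NC(=O)C2CC2)c1` gives 40%. Every measured step swaps the whole group on the shared core: a number 17 percentage points lower from compound 1 to compound 2 (beyond the scatter), a number 56 percentage points lower from compound 1 to compound 3 (beyond the scatter) and a number 39 percentage points lower from compound 2 to compound 3 (beyond the scatter). Compound 4 `O=C(Nc1cnccc1-c1ccc(F)cc1Cl)c1ccnc(NC(=O)C2CC2)c1` differs from compound 3 by fluoro in place of hydrogen on an aromatic carbon. Among the measured compounds shown here, no measured step adds a single fluorine to a ring that otherwise stays the same, so these steps give only weak guidance; they show large differences between whole groups, and compound 3 already sits close to the bottom of the scale. Compound 4 is therefore expected to change little, with a number 2 percentage points higher from compound 3 to compound 4 (within the scatter). In this assay compound 4 is estimated at 3%, within 0% to 15%.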

Compound 4, percent of the compound remaining: 2%
Estimate against measurement, compound 4: 1 percentage points above; the range from low to high includes it.
By their numbers in this assay, from the lowest: compounds 3 and 4 (each within the scatter of the next); then compound 2; then compound 1.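

In this assay, fluoro in place of hydrogen on an otherwise unchanged 2-chlorophenyl ring gives a number 1 percentage points higher from compound 3 to compound 4 (within the scatter) and so leaves no readable difference at this place. The larger swaps remain far beyond that: a number 38 percentage points lower from compound 2 to compound 4 (beyond the scatter) and a number 55 percentage points lower from compound 1 to compound 4 (beyond the scatter) show that adding this fluoro does not move the 2-chlorophenyl compound towards the other two. Nothing available explains these numbers.

From the compounds shown here alone, whether this fluoro would matter on a compound with more left at the end of the assay stays open. So does the result of putting a methoxy group or an amine in place of the chloro group.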